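The compounds below may be only part of what the source reports. "The series", "measured", "known", "first", "only" and "open" are said of these compounds alone.

In a functional assay on the whole organism (strain albino) for inhibition, with Rattus norvegicus as the target, read by paw edema, with stated times of 30 min and 2 h, at a dose of 0.28 mmol/kg by the oral route (a lower number here means less inhibition, a higher number more inhibition at the dose given (going by the name of the read-out)), compound 3 `CCn1c(SCC(=O)Nc2ccc(C(C)=O)cc2)nnc1-c1ccc(OC)cc1` gives 54%. Compound 1 `C=CCn1c(SCC(=O)Nc2ccc(C(C)=O)cc2)nnc1-c1ccccc1` gives 52%, and compound 2 `CCn1c(SCC(=O)Nc2ccc(C(C)=O)cc2)nnc1-c1ccc(OC)c(OC)c1` gives 59% in this assay. On these three numbers compound 3 stands second, yet its gaps to compound 1 and to compound 2 are both within the scatter, so no ordering among them can be read. For the measured compounds named here, the one measured step of the same kind, a number 5 percentage points lower from compound 2 to compound 3 (within the scatter), was within the scatter. Compound 4 `CCn1c(SCC(=O)Nc2ccc(C(C)=O)cc2)nnc1-c1ccccc1` differs from compound 3 in one place: hydrogen in place of methoxy on an aromatic carbon. Because that earlier step a number 5 percentage points lower from compound 2 to compound 3 (within the scatter) stayed within the scatter, compound 4 is expected to show no movement beyond the scatter, a step of a number 4 percentage points lower from compound 3 to compound 4 (within the scatter). Compound 4 is therefore estimated at 50%, within 40% to 60%.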

Compound 4, a percentage reported as inhibition, in the whole organism at one dose (the size of the read-out at that dose, not a potency): 53%
The estimate for compound 4 lay 3 percentage points below the measured number, within the range that was stated.
By their numbers in this assay, from the lowest: compounds 1, 4, 3 and 2 (each within the scatter of the next).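

In this assay, the change from 4-methoxyphenyl to phenyl is a number 1 percentage points lower from compound 3 to compound 4 (within the scatter), and phenyl in place of 3,4-dimethoxyphenyl is a number 6 percentage points lower from compound 2 to compound 4 (within the scatter), so neither the single nor the double methoxy substitution is needed to keep the number at this dose. Methyl in place of vinyl on the chain bound to the aromatic nitrogen is a number 1 percentage points higher from compound 1 to compound 4 (within the scatter), so that change also leaves no readable mark on the unsubstituted phenyl series. Nothing measured here speaks to the reason for this flatness. On these data alone, whether an amine or a carboxylic acid at this ring position would move the number beyond the scatter remains open. So does whether these compounds would separate at other doses.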